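The source may report more compounds than this note shows. Statements on the series, on what has been measured and on what is new or still open speak of the compounds shown alone.

Compound 1, `Fc1ccc(-c2ccc3c(NCCCNCc4ccco4)ccnc3c2)cc1`: 7760 nM
Compound 2, `COc1ccc(Oc2ccc3c(NCCCNCc4ccco4)ccnc3c2)cc1`: 5300 nM
Compound 3, `c1coc(CNCCCNc2ccnc3cc(-c4cccc5ccccc45)ccc23)c1`: 5600 nM

These three compounds share one core and differ only in the group attached to a single aromatic carbon. In an ADME assay on HepG2 cells (Homo sapiens) for cytotoxicity, read by luminescence, CellTiter-Glo and ATP content, with a stated time of 72 h (on this read-out higher numbers stand for an effect only at larger amounts of compound and lower numbers for an effect already at smaller amounts), compound 3 gives 5600 nM, the second highest of the three numbers; the nearest is compound 2, with a 1.1-fold higher number from compound 2 to compound 3 (0.02 log units; within the scatter), and the furthest is compound 1, with a 1.4-fold lower number from compound 1 to compound 3 (0.14 log units; within the scatter). Compound 4, `c1ccc(Cc2ccc3c(NCCCNCc4ccco4)ccnc3c2)cc1`, has not yet been measured. It differs from compound 3 as follows: benzyl in place of naphthalen-1-yl on an aromatic carbon. All three measured steps are swaps of one aromatic group for another at this same place: a 1.5-fold lower number from compound 1 to compound 2 (0.17 log units; within the scatter), a 1.4-fold lower number from compound 1 to compound 3 (0.14 log units; within the scatter) and a 1.1-fold higher number from compound 2 to compound 3 (0.02 log units; within the scatter). None of them moved the number beyond the scatter. A further swap of this kind is therefore expected to leave this assay roughly unchanged, with no step beyond the scatter in either direction. Compound 4 is expected to give 6500 nM, in a range from 3000 nM to 14000 nM. This estimate means a 1.2-fold higher number from compound 3 to compound 4 (0.06 log units; within the scatter).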

Compound 4, half-maximal effective concentration: 16000 nM
The estimate for compound 4 lay 2.5-fold (0.39 log units) below the measured number; the measured number lies above the stated range.
By their numbers in this assay, from the lowest: compounds 2, 3 and 1 (each within the scatter of the next); then compound 4.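

In this assay, among the compounds shown here, the group on this aromatic carbon turns out to matter, since benzyl gives the first steps beyond the scatter, all of modest size and all in the same direction (a 2.9-fold higher number from compound 3 to compound 4 (0.46 log units; beyond the scatter); a 3.0-fold higher number from compound 2 to compound 4 (0.48 log units; beyond the scatter); a 2.1-fold higher number from compound 1 to compound 4 (0.31 log units; beyond the scatter)). Counting rings does not explain the gap: benzyl brings one six-membered aromatic ring where naphthalen-1-yl brings two, but 4-fluorophenyl in compound 1 also carries a single ring and still stays within the scatter of compound 2 and compound 3. Nothing available here accounts for the benzyl result.

The compounds shown leave open whether a group with no aromatic ring, such as an amine, a carboxylic acid or a longer chain, would shift the number further at this carbon. They also leave open whether other groups would separate from the first three as benzyl does.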